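Working notes: from compound 3 to compound 4

The compounds below may be only part of what the source reports. "The series", "measured", "known", "first", "only" and "open" are said of these compounds alone.

Measured so far in a functional assay on DU-145 cells (Homo sapiens) for inhibition, read by trypan blue exclusion, with a stated time of 96 h (a higher number here means a weaker inhibitor of growth, a lower number a stronger inhibitor of growth), as follows
- compound 1 `O=C(/C(=C\c1ccc(Cl)cc1Cl)S(=O)(=O)c1ccc(Br)cc1)c1ccc(Cl)cc1` gives 50000 nM for growth inhibition
- compound 2 `CCOc1ccc(/C=C(/SCc2ccc(F)cc2)C(=O)c2ccc(Br)cc2)cc1OC` gives 50000 nM for growth inhibition
- compound 3 `COc1ccc(/C=C(\C(=O)c2ccc(Br)cc2)S(=O)(=O)c2ccc(Br)cc2)c(F)c1` gives 10000 nM for growth inhibition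

Compound 3 with 10000 nM has the lowest of the three numbers and lies beyond the scatter from both compound 1 and compound 2, which show the same number.

Among the measured compounds shown here, compound 4 `O=C(/C(=C\c1ccc(F)cc1F)S(=O)(=O)c1ccc(Br)cc1)c1ccc(Br)cc1` has no measurement yet. It differs from compound 3 by fluoro in place of methoxy on an aromatic carbon (fluoro in place of methoxy on an aromatic carbon, 2-fluoro-4-methoxyphenyl to 2,4-difluorophenyl). For the measured compounds named here, no measured pair isolates this change, so the evidence is indirect and thin.

Compound 1 also lacks a methoxy group on the corresponding ring and gives 50000 nM in this assay as its number, so a weaker inhibitor of growth than compound 3 is expected. The estimated move is toward a higher number, modest in size and just beyond the scatter: a 2.5-fold higher number from compound 3 to compound 4 (0.40 log units; beyond the scatter) (estimate only). Compound 4 is expected at 25000 nM (range 8000 nM to 50000 nM).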

Compound 4, concentration for 50% growth inhibition: 7500 nM
Beside the measured number, compound 4's estimate is 3.3-fold (0.52 log units) above it, outside the stated range (below it).
By their numbers in this assay, from the lowest: compounds 4 and 3 (each within the scatter of the next); then compounds 1 and 2 (each within the scatter of the next).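

In this assay, the step of a 1.3-fold lower number from compound 3 to compound 4 (0.12 log units; within the scatter) gives the series its first pair that differs in one place, and it isolates fluoro in place of methoxy on the aromatic carbon para to a large group. The 2-fluoro-4-methoxyphenyl and 2,4-difluorophenyl compounds cannot be told apart here, so within this pair growth inhibition does not depend on the methoxy group or on the hydrogen-bond acceptor counted with it. Nothing on hand accounts for this match between the two compounds.

As far as these compounds go, whether a different group at this position, such as an amine or a carboxylic acid, would move the number beyond the scatter remains open. Changes elsewhere on the shared core also remain open, with no pair yet isolating any of them.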